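The compounds below may be only part of what the source reports. "The series", "measured", "known", "first", "only" and "open" are said of these compounds alone.

Measured in a functional assay on HepG2 cells (Homo sapiens) for cytotoxicity, with a stated time of 72 h; a higher number here means that more compound is needed for the effect, a lower number that less compound is needed; every entry is a limit, not a number:
- compound 1 `C=C[C@@](C)(/C=C/c1ccc(OCc2ccccc2)cc1)CCC=C(C)C`: > 52000 nM
- compound 2 `C=C[C@@](C)(/C=C/c1ccc(O)c(/C=C/C#N)c1)CCC=C(C)C`: > 52000 nM
- compound 3 `COc1ccc(/C=C/[C@@](C)(/C=C/c2ccc(O)c(C=O)c2)CCC=C(C)C)cc1`: > 26000 nM

Compound 3 gives only a limit, (the limit of > 26000 nM in this assay, at which 1 of the 3 values shown sits). Among the measured compounds shown here, no number fixes its position, and no step between measured compounds can be read.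

Compound 4 `COc1ccc(/C=C/[C@@](C)(/C=C/c2ccc(O)c(/C=C/C#N)c2)CCC=C(C)C)cc1` takes 2-cyanoethenyl in place of formyl on an aromatic carbon, ortho to a hydroxy group (2-cyanoethenyl in place of formyl on an aromatic carbon).

No step beyond the scatter is expected in this assay, and no direction can be favoured. The expectation rests on compound 2, which carries the same 2-cyanoethenyl and whose entry is the limit > 52000 nM. The series holds no measured number that would point to a gain in cytotoxicity, so a further limit is the likeliest report for the new compound.

The estimated change is a step that the limit leaves unreadable from compound 3 to compound 4, expected to stay within the scatter.

For compound 4 the estimated value is 40000 nM, with an expected range of 15000 nM to 60000 nM.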

Compound 4, half-maximal effective concentration: > 26000 nM
Compound 4 gave a limit, no number; the forecaster's own chance of this, stated with the estimate: 75%; the middle value does not contradict the limit.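

Compound 2, compound 3 and compound 4 all give limits rather than numbers in this assay, and neither step into compound 4 can be read. The compounds shown leave open whether 2-cyanoethenyl in place of formyl changes the result in this assay at all.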